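This account rests on a few compounds, and the source may have more. Where it says the series, first, only, none or still open, it means among the compounds named here.

Measured so far in a functional assay on HT-29 cells (Homo sapiens) for antiproliferative activity, read by MTT assay, with a stated time of 72 h; on this read-out higher numbers stand for weaker inhibition and lower numbers for stronger inhibition:
Compound 1 `COc1cc(-c2nccn2C)cc(OC)c1OC`: > 100000 nM
Compound 2 `COc1cc(-c2nccn2-c2ccc(C)cc2)cc(OC)c1OC`: 1600 nM

The entry for compound 1 is a limit of this assay, not a number. For the measured compounds named here, compound 2, at 1600 nM, holds the only actual number so far. Compound 3 `COc1cc(-c2nccn2-c2ccc(F)cc2)cc(OC)c1OC` differs from it by one change, fluoro in place of methyl on an aromatic carbon, para to a large group. Going by the values given here, the sole measured step, an at least 62-fold lower number from compound 1 to compound 2 (1.79 log units; beyond the scatter), was large, but it concerned 4-methylphenyl in place of methyl on an aromatic nitrogen, so it bears only indirectly on this change. A modest move towards higher numbers in this assay is therefore expected, though a step within the scatter remains possible. The expected step is a 1.6-fold higher number from compound 2 to compound 3 (0.19 log units; within the scatter). For compound 3 the estimated value is 2500 nM, with an expected range of 700 nM to 10000 nM.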

Compound 3, half-maximal inhibitory concentration: 29300 nM
Beside the measured number, compound 3's estimate is 12-fold (1.07 log units) below it; the measured number lies above the stated range.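

In this assay, the substituent on an aromatic carbon, para to a large group, proves to matter: fluoro in place of methyl gives an 18-fold higher number from compound 2 to compound 3 (1.26 log units; beyond the scatter) and so loses most of what compound 2 had gained. An aryl group on the aromatic nitrogen still helps with 4-fluorophenyl, with an at least 3.4-fold lower number from compound 1 to compound 3 (0.53 log units; beyond the scatter) as the step. That step is only a bound, as the entry for compound 1 is a limit of the assay: the limit of > 100000 nM in this assay, at which 1 of the 3 values shown sits.

What separates methyl from fluoro here remains unexplained. From the compounds shown here alone, how chloro, an amine or a longer chain at this place would compare with methyl remains open.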